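The compounds below may be only part of what the source reports. "The series", "measured", "known", "first", "only" and "open" are said of these compounds alone.

Working notes on the series. The shared core is that of compound 1 `O=C(/C=C/CN1CCCCC1)Nc1cc2c(Nc3ccc(F)c(Cl)c3)ncnc2cc1O[C@H]1CCOC1`. In a functional assay on NCI-H1975 cells (Homo sapiens) for inhibition (on this read-out lower numbers stand for stronger inhibition of growth and higher numbers for weaker inhibition of growth), compound 1 gives 168 nM, the highest of the two numbers recorded so far; its nearest neighbour is compound 3 `O=C(/C=C/CNC1CC1)Nc1cc2c(Nc3ccc(F)c(Cl)c3)ncnc2cc1O[C@H]1CCOC1`, which in this assay gives 10.2 nM. Compound 2 `O=C(/C=C/CN(C1CC1)C1CC1)Nc1cc2c(Nc3ccc(F)c(Cl)c3)ncnc2cc1O[C@H]1CCOC1` has no result in this assay: for compound 2 the entry reads "not determined" (no result reported). Going by the values given here, the one measured step, a 16-fold lower number from compound 1 to compound 3 (1.22 log units; beyond the scatter), concerns the cyclopropylamino in place of piperidin-1-yl on the saturated chain carbon, not the nitrogen on the aromatic ring.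

Compound 4 `C#Cc1cccc(Nc2ncnc3cc(O[C@H]4CCOC4)c(NC(=O)/C=C/CN4CCCCC4)cc23)c1` differs from compound 1 by 3-ethynylphenyl in place of 3-chloro-4-fluorophenyl on a nitrogen on an aromatic ring. Among the compounds with values here, no measured step touches this nitrogen on the aromatic ring; the step of a 16-fold lower number from compound 1 to compound 3 (1.22 log units; beyond the scatter) sits elsewhere in the structure and gives no guide here. The numbers gathered so far therefore give no reason to expect a step beyond the scatter in this assay in either direction, and the expectation is kept close to compound 1 with a wide band. Compound 4 is thus expected to give 170 nM, within 45 nM to 650 nM. The expected step is a 1.0-fold higher number from compound 1 to compound 4 (0.01 log units; within the scatter), within the scatter.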

Compound 4, concentration for 50% growth inhibition: 40.1 nM
Estimate against measurement, compound 4: 4.2-fold (0.63 log units) above, and the stated range ends above it.
By their numbers in this assay, from the lowest: compound 3; then compound 4; then compound 1.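

In this assay the group on this nitrogen on the aromatic ring proves able to move the read-out, with a 4.2-fold lower number from compound 1 to compound 4 (0.62 log units; beyond the scatter) for 3-ethynylphenyl in place of 3-chloro-4-fluorophenyl, the first step read at this place. The change swaps the two halogens and leaves the count of heavy atoms the same, so the step is not tied to a change in that count. It holds so far only with piperidin-1-yl on the saturated chain carbon, and nothing at hand bears on why the number falls.

Open, as far as these compounds go, is whether the 3-ethynylphenyl step carries over to the cyclopropylamino side chain of compound 3. Also open, from the compounds shown here alone, is which part of the change counts, since a 3-ethynyl-4-fluorophenyl or a 3-chlorophenyl group on the same nitrogen would separate the ethynyl group from the halogens.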